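Halogenated benzylthio analogues in the shared series

The source may report more compounds than this note shows. Statements on the series, on what has been measured and on what is new or still open speak of the compounds shown alone.

Measured compounds:
compound 1 `O=C(O)Cn1c(SCCc2ccccc2)nc2ccccc21`, 881 nM
compound 2 `CCOC(=O)CCSc1nc2ccccc2n1CC(=O)O`, 11400 nM
compound 3 `O=C(O)Cn1c(SCc2ccccc2Cl)nc2ccccc21`, 370 nM

Read-out is an assay on HEK293 cells for displacement of a labelled ligand from prostaglandin D2 receptor 2 (Homo sapiens); on this read-out higher numbers stand for weaker inhibition and lower numbers for stronger inhibition. Compound 3 gives the lowest number of the three; the nearest is compound 1, reached by a 2.4-fold lower number from compound 1 to compound 3 (0.38 log units; beyond the scatter), and the furthest is compound 2, reached by a 31-fold lower number from compound 2 to compound 3 (1.49 log units; beyond the scatter). Compound 2 is the weakest, with a 13-fold higher number from compound 1 to compound 2 (1.11 log units; beyond the scatter) setting it apart from compound 1 as well.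

Compound 4 `O=C(O)Cn1c(SCc2ccc(Br)cc2)nc2ccccc21` is not yet measured. It differs from compound 3 by 4-bromophenyl in place of 2-chlorophenyl on a saturated chain carbon bound to a sulfur. Among the compounds with values here, no measured step covers a halogen swap on the aryl ring at this position. The step from compound 1 to compound 3 shows that placing a 2-chlorophenyl here, in place of benzyl, moves the number only modestly, so the aryl substitution pattern at this carbon appears to matter less than the exchange of phenyl for ethoxycarbonyl seen from compound 1 to compound 2. Compound 4 is therefore expected to remain near compound 3, with a step no larger than the scatter, if anything a slightly higher number: a 1.5-fold higher number from compound 3 to compound 4 (0.17 log units; within the scatter). The estimate for compound 4 is 550 nM, between 200 nM and 1500 nM.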

Compound 4, half-maximal inhibitory concentration: 220 nM
For compound 4 the middle estimate is 2.5-fold (0.40 log units) above the measured one, within the range that was stated.
By their numbers in this assay, from the lowest: compounds 4 and 3 (each within the scatter of the next); then compound 1; then compound 2.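

In this assay the change to 4-bromophenyl in place of 2-chlorophenyl on a saturated chain carbon bound to a sulfur gives a 1.7-fold lower number from compound 3 to compound 4 (0.23 log units; within the scatter) and so does not separate the two aryl groups, even though the halogen and its place on the ring both differ. The separation from the other side chains seen with compound 3 also holds with a different halogenated phenyl: a 4.0-fold lower number from compound 1 to compound 4 (0.60 log units; beyond the scatter) against benzyl, and a 52-fold lower number from compound 2 to compound 4 (1.71 log units; beyond the scatter) against (ethoxycarbonyl)methyl, so at this position it is not tied to 2-chlorophenyl alone. No measurement at hand offers a reason for these steps.

Going by these compounds, because compound 3 and compound 4 differ in both the halogen and its ring place, the contribution of each stays open, and 4-chlorophenyl or 2-bromophenyl would take the two apart. Unsubstituted phenyl on the same carbon would show whether a halogen is needed at all, and a pyridine ring or a 4-methoxyphenyl would show how far this position tolerates groups other than halogenated phenyl.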